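The source may report more compounds than this note shows. Statements on the series, on what has been measured and on what is new or still open speak of the compounds shown alone.

Compound 1 `C#CCCOC(=O)c1ccc(C(CC)(CC)c2ccc(C#CC(O)(CC)CC)c(C)c2)n1CC`: > 50000 nM (a limit)
Compound 2 `CCn1cc(C(CC)(CC)c2ccc(C#CC(O)(CC)CC)c(C)c2)cc1C(=O)NCCN(C)C`: 10100 nM

Within the data shown here, in a functional assay on PC-3 cells (Homo sapiens) for antiproliferative activity, read by MTT assay, with a stated time of 72 h (on this read-out lower numbers stand for stronger inhibition and higher numbers for weaker inhibition), compound 2 gives 10100 nM, the only actual number so far. Compound 1 is reported as > 50000 nM, which is a limit of the assay and not a number.

Compound 3 `CCn1cc(C(CC)(CC)c2ccc(C#CC(O)(CC)CC)c(C)c2)cc1C(=O)N[C@@H](C(=O)O)C(C)C` keeps the core of compound 2 and changes the amide substituent: 1-carboxy-2-methylpropyl in place of 2-(dimethylamino)ethyl on an amide-type nitrogen. 1-Carboxy-2-methylpropyl stands in place of 2-(dimethylamino)ethyl on an amide-type nitrogen. Among the measured compounds shown here, no measured step sizes this change, so the expectation is only weakly grounded. For the measured compounds named here, it rests on compound 2 at 10100 nM being the only compound to give a number. The expected change is towards weaker inhibition, a step of a 2.5-fold higher number from compound 2 to compound 3 (0.39 log units; beyond the scatter). For compound 3 the estimate is 25000 nM, with an expected range of 8000 nM to 60000 nM.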

Compound 3, half-maximal inhibitory concentration: 10300 nM
For compound 3 the middle estimate is 2.4-fold (0.39 log units) above the measured one, within the range that was stated.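

At the amide-type nitrogen, 1-carboxy-2-methylpropyl in place of 2-(dimethylamino)ethyl gives, in this assay, a 1.0-fold higher number from compound 2 to compound 3 (0.01 log units; within the scatter). Among these compounds, this is the first sized step at this position, and the read-out does not tell the two groups apart, even though one carries a dimethylamino end and the other a carboxy group with a defined stereocentre. Both compounds give actual numbers, so this step is not cut off by the assay limit, which applies to only one value in the series: the limit of > 50000 nM in this assay, at which 1 of the 3 values shown sits.

Still open, on these data alone, is whether any group on this nitrogen separates from these two, for example an unsubstituted amide, a morpholine-bearing chain or a longer chain such as 3-(dimethylamino)propyl. As far as these compounds go, the opposite stereocentre of the 1-carboxy-2-methylpropyl group is also open.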